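This account rests on a few compounds, and the source may have more. Where it says the series, first, only, none or still open, it means among the compounds named here.

Compound 1 `CCN(CC)CC(=O)Nc1ccc(-c2nc3cc(C(F)(F)F)ccc3n2C)cc1` carries a diethylamino group on the chain next to the amide carbonyl, and in an ADME assay on BHK cells (Mesocricetus auratus) for cytotoxicity, read by MTT assay, with a stated time of 96 h (on this read-out higher numbers stand for lower toxicity in this test and lower numbers for higher toxicity in this test), compound 1 gives 16000 nM. Compound 2 `CCN(CC)CC(=O)Nc1ccc(-c2nc3cc(C(F)(F)F)ccc3[nH]2)cc1` differs from it by hydrogen in place of methyl on an aromatic nitrogen; in this assay compound 2 gives 23000 nM, so the change brought a 1.4-fold higher number from compound 1 to compound 2 (0.16 log units; within the scatter). Compound 3 `Cn1c(-c2ccc(NC(=O)CN3CCN(c4ccccc4)CC3)cc2)nc2cc(C(F)(F)F)ccc21` differs from compound 1 by 4-phenylpiperazin-1-yl in place of diethylamino on a saturated chain carbon bound to a carbonyl carbon, and in this assay compound 3 gives 100000 nM, the step being a 6.3-fold higher number from compound 1 to compound 3 (0.80 log units; beyond the scatter). Compound 3 thus stands highest of the three measured numbers in this assay.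

Compound 4 `O=C(CN1CCN(c2ccccc2)CC1)Nc1ccc(-c2nc3cc(C(F)(F)F)ccc3[nH]2)cc1` is not yet measured. It differs from compound 3 by hydrogen in place of methyl on an aromatic nitrogen, the same change as that from compound 1 to compound 2, made on the core of compound 3 rather than that of compound 1. Since that change gave only a 1.4-fold higher number from compound 1 to compound 2 (0.16 log units; within the scatter), the step from compound 3 to compound 4 in this assay is expected to be about a 1.3-fold higher number from compound 3 to compound 4 (0.11 log units; within the scatter). On that basis compound 4 is estimated at 130000 nM in this assay, with a plausible range from 50000 nM to 300000 nM.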

Compound 4, half-maximal cytotoxic concentration: > 100000 nM
Compound 4 ended at the assay's limit; the forecaster's own chance of this, stated with the estimate: 30%; the middle value lies beyond the limit too.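

In this assay compound 4 gives > 100000 nM, which is a limit of the assay and not a number. Hydrogen in place of methyl on an aromatic nitrogen can therefore be followed on two cores, though only one of the two steps has a readable size: the same change on two cores in this assay, a 1.4-fold higher number (0.16 log units; within the scatter) from compound 1 to compound 2 and a number no lower (the limit leaves the size open) from compound 3 to compound 4; the limit leaves it open whether they differ. The new step is a number no lower from compound 3 to compound 4 (the limit leaves the size open) and its size cannot be read. This shows that neither core gives a lower number with this change, but it does not show that the change carries over from one core to the other with the same size, since the step on the core of compound 3 cannot be read.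

The compounds shown leave open how an ethyl or an acetyl group on that aromatic nitrogen would read in this assay, and whether the change behaves alike with a morpholin-4-yl or dimethylamino group in place of diethylamino. They also leave open what happens on either core when chlorine or a nitrile stands in place of trifluoromethyl.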